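A few compounds are considered here, and "the series" means these few. Any claim that something is new, unique, unknown or untested is made for them only; others in the source may bear on it.

In a functional assay on K562 cells (Homo sapiens), read by MTT assay, with a stated time of 72 h (on this read-out higher numbers stand for weaker inhibition and lower numbers for stronger inhibition), two nucleosides sharing one core have been measured. Compound 1 `COc1ncnc2c1c(-c1ccccc1)cn2[C@@H]1O[C@H](CO)[C@@H](O)[C@H]1O`, which bears phenyl, reads > 20000 nM; this is a limit of the assay and not a number. Among the compounds with values here, compound 2 `COc1ncnc2c1c(-c1cc3ccccc3o1)cn2[C@@H]1O[C@H](CO)[C@@H](O)[C@H]1O`, which bears 1-benzofuran-2-yl, gives 13100 nM, the only actual number so far. Within the data shown here, the one measured step is an at least 1.5-fold lower number from compound 1 to compound 2 (0.18 log units; that floor lies within the scatter), and it shows no change beyond the scatter. Compound 3 `C#Cc1cn([C@@H]2O[C@H](CO)[C@@H](O)[C@H]2O)c2ncnc(OC)c12` carries ethynyl in place of 1-benzofuran-2-yl on an aromatic carbon. That measured step bears on this change only loosely, as it does not involve ethynyl, so the direction stays uncertain and only a modest move toward a lower number in this assay is expected. The expected step is a 1.9-fold lower number from compound 2 to compound 3 (0.27 log units; within the scatter). The value estimated for compound 3 is 7000 nM, with an expected range from 1000 nM to 20000 nM.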

Compound 3, half-maximal inhibitory concentration: 380 nM
For compound 3 the middle estimate is 18-fold (1.27 log units) above the measured one; the measured number lies below the stated range.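

In this assay this position now shows a clear response, which the exchange of phenyl for 1-benzofuran-2-yl had not shown: ethynyl in place of 1-benzofuran-2-yl gives a 34-fold lower number from compound 2 to compound 3 (1.54 log units; beyond the scatter). Ethynyl in place of phenyl gives an at least 52-fold lower number from compound 1 to compound 3 (1.72 log units; beyond the scatter), so among these three compounds the one group with no ring carries the lowest number. Compound 1 stands at a limit of the assay and not at a number, so the full size of that second step cannot be read: the limit of > 20000 nM in this assay, at which 1 of the 3 values shown sits.

The compounds shown leave open whether the lower number follows the triple bond itself or the loss of the aromatic rings, a question that ethyl or a bare hydrogen at this place would address. They also leave open whether a longer chain on the triple bond, or an amine at its end, would keep the number this low.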